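An Ethoxy Step Repeated on a Second Amide Core

The source may hold more compounds than are shown below. What is called first, only, known or untested is meant among the compounds shown, and "the series" means these compounds.

Of the compounds shown here, three built on one shared core have been measured in a physicochemical assay, with a stated time of 30 min; a higher number here means a weaker inhibitor, a lower number a stronger inhibitor. Compound 1 `COc1cccc(NC(=O)C2Cc3cc(OC)c(OC)cc3C2=O)c1` gives 38.9 ug/mL. Compound 2 `CCOc1cccc(NC(=O)C2Cc3cc(OC)c(OC)cc3C2=O)c1` gives 44.9 ug/mL, and compound 3 `COc1ccccc1NC(=O)C1Cc2cc(OC)c(OC)cc2C1=O` gives 45.8 ug/mL. The change from compound 1 to compound 2 is methyl in place of hydrogen on a saturated chain carbon bound to an oxygen on an aromatic ring, and its step was a 1.2-fold higher number from compound 1 to compound 2 (0.06 log units; within the scatter). The two cores differ as 2-methoxyphenyl in place of 3-methoxyphenyl on an amide-type nitrogen, a step of a 1.2-fold higher number from compound 1 to compound 3 (0.07 log units; within the scatter). Compound 4 `CCOc1ccccc1NC(=O)C1Cc2cc(OC)c(OC)cc2C1=O` has not yet been measured; it differs from compound 3 by methyl in place of hydrogen on a saturated chain carbon bound to an oxygen on an aromatic ring, at a place described in the same words as before, so it is the same change. Because the step of a 1.2-fold higher number from compound 1 to compound 2 (0.06 log units; within the scatter) stayed within the scatter, compound 4 is expected to show a step of about a 1.1-fold higher number from compound 3 to compound 4 (0.04 log units; within the scatter) in this assay. Compound 4 is therefore estimated at 50 ug/mL, with a range from 30 ug/mL to 85 ug/mL.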

Compound 4, half-maximal inhibitory concentration: 63.7 ug/mL
The estimate for compound 4 lay 1.3-fold (0.11 log units) below the measured number, within the range that was stated.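

In this assay the change from methoxy to ethoxy gave a 1.4-fold higher number from compound 3 to compound 4 (0.14 log units; within the scatter) and, on the core of compound 1, it gave a 1.2-fold higher number from compound 1 to compound 2 (0.06 log units; within the scatter), so on both cores the step stays within the usual scatter of repeated measurements. Going by these compounds alone, this shows that the change carried from one core to the other without a step beyond that scatter, but with only two pairs it does not show that ethoxy truly shifts the number, or that the two steps are truly alike. No measurement shown here explains these numbers.

The compounds shown leave open what a longer chain such as propoxy, or an amine or a carboxylic acid at the end of that chain, would do in this assay. They also leave open whether the methoxy to ethoxy step would stay this small on a third core.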